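The source may hold more compounds than are shown below. What is called first, only, known or untested is meant among the compounds shown, and "the series" means these compounds.

Compound 3 `O=Cc1ccc(-c2cn3ccnc3c(-c3ccc4ncn(Cc5ccccc5)c4c3)n2)cc1` stands highest of the three compounds measured in a functional assay on HCT-116 cells (Homo sapiens) for inhibition, read by sulforhodamine B assay, with a stated time of 48 h, tested at 10 uM; a higher number here means more inhibition at the concentration tested (going by the name of the read-out), a lower number less inhibition: in this assay compound 3 gives 92.6%, while its nearest neighbour, compound 2 `CCc1ccc(-c2cn3ccnc3c(-c3ccc4ncn(Cc5ccccc5)c4c3)n2)cc1`, gives 61.2%, and the furthest, compound 1 `c1ccc2c(-c3cn4ccnc4c(-c4ccc5ncn(C6CCCCC6)c5c4)n3)cccc2c1`, gives 17.9%. The unmeasured compound 4 `c1ccc(Cn2cnc3ccc(-c4nc(-c5cccc6ccccc56)cn5ccnc45)cc32)cc1` differs from compound 3 in one place: naphthalen-1-yl in place of 4-formylphenyl on an aromatic carbon. Among the compounds with values here, one measured step bears on this change. The replacement of ethyl by formyl on the aromatic carbon produced a number 31.4 percentage points higher from compound 2 to compound 3 (beyond the scatter), so removing the formyl group again, here in favour of a hydrocarbon group, is expected to undo much of that gain. Compound 1 carries the same naphthalen-1-yl group, though it differs from compound 4 in another part of the molecule, and its low value in this assay points the same way. A downward step of a number 57.6 percentage points lower from compound 3 to compound 4 (beyond the scatter) is therefore expected. Compound 4 is estimated to give 35% in this assay, within a range from 10% to 62%.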

Compound 4, a percentage reported as inhibition, at one concentration (the size of the read-out at that concentration, not a potency): 32.9%
Compound 4: middle estimate off by 2.1 percentage points, on the high side; the range from low to high includes it.
By their numbers in this assay, from the lowest: compound 1; then compound 4; then compound 2; then compound 3.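

At this position, naphthalen-1-yl is a much poorer replacement for 4-formylphenyl in this assay, with a number 59.7 percentage points lower from compound 3 to compound 4 (beyond the scatter). It also falls short of the hydrocarbon-bearing 4-ethylphenyl, with a number 28.3 percentage points lower from compound 2 to compound 4 (beyond the scatter), so the loss from the formyl compound is not simply the loss of the formyl group. Within the data shown here, with naphthalen-1-yl held in place, benzyl in place of cyclohexyl on the aromatic nitrogen gives a number 15 percentage points higher from compound 1 to compound 4 (beyond the scatter), the first direct reading of that change, although no available evidence explains any of these steps.

From the compounds shown here alone, it remains open how an amine or a carboxylic acid in place of the formyl group would read in this assay. Going by these compounds, it is also open whether the step from cyclohexyl to benzyl would be of similar size with 4-formylphenyl in place of naphthalen-1-yl.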